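The compounds below may be only part of what the source reports. "The series", "measured", "known", "first", "only" and "open" are said of these compounds alone.

Compound 3, `c1coc(CNCCCNc2ccnc3cc(CC4CCCCC4)ccc23)c1`, is one of three compounds that share a core and differ only in the group carried on one aromatic carbon. In an ADME assay for permeability, using PAMPA, with a stated time of 30 min, at pH 7.4 (on this read-out higher numbers stand for higher permeability and lower numbers for lower permeability), compound 3 gives 23 10^-6 cm/s. Compound 1, `CC(C)Cc1ccc2c(NCCCNCc3ccco3)ccnc2c1`, gives 23 10^-6 cm/s in this assay, and compound 2, `CCC(CC)c1ccc2c(NCCCNCc3ccco3)ccnc2c1`, gives 23 10^-6 cm/s, so compound 3 stands level with both on this read-out. The steps measured so far, no change at the digits printed from compound 1 to compound 2 (within the scatter), no change at the digits printed from compound 1 to compound 3 (within the scatter) and no change at the digits printed from compound 2 to compound 3 (within the scatter), all show that exchanging one of these groups for another left the read-out where it was. Compound 4, `c1coc(CNCCCNc2ccnc3cc(-c4cccc5ccccc45)ccc23)c1`, is not yet measured; it differs from compound 3 by naphthalen-1-yl in place of cyclohexylmethyl on an aromatic carbon. The earlier steps shown here bear on this change only loosely, since none of them brought in an aromatic group, but every one of them left the value unchanged. The step expected from this change, a 1.2-fold lower number from compound 3 to compound 4 (0.06 log units; within the scatter), is therefore no change beyond the scatter. Compound 4 is estimated at 20 10^-6 cm/s, with an expected range from 10 10^-6 cm/s to 40 10^-6 cm/s.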

Compound 4, apparent permeability: 237 10^-6 cm/s
Compound 4: the middle estimate sits 12-fold (1.07 log units) below what was measured, outside the stated range (above it).
By their numbers in this assay, from the lowest: compounds 1, 2 and 3 (each within the scatter of the next); then compound 4.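

This position is not indifferent to what it carries: isobutyl, pentan-3-yl and cyclohexylmethyl gave the same reading in this assay, yet naphthalen-1-yl on the same aromatic carbon gives a 10-fold higher number from compound 3 to compound 4 (1.01 log units; beyond the scatter), along with a 10-fold higher number from compound 2 to compound 4 (1.01 log units; beyond the scatter) and a 10-fold higher number from compound 1 to compound 4 (1.01 log units; beyond the scatter). The flat result among the first three compounds therefore held only for those non-aromatic groups, and it does not extend to this group with two six-membered aromatic rings of carbon. No supporting measurement is available to explain the rise.

With a single aromatic group in the set, the result cannot show whether phenyl on this carbon would give a similar reading, or whether naphthalen-2-yl would match naphthalen-1-yl. On these data alone, what an amine or a carboxylic acid at this place would give also remains open.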